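A few compounds are considered here, and "the series" means these few. Any claim that something is new, unique, unknown or untested is made for them only; others in the source may bear on it.

Working notes on the series. Of the compounds shown here, two have been measured so far. Compound 1 `Cc1ccc2c3c(n(C)c(=O)c2c1)-c1ccccc1OCC3` gives 30300 nM in a functional assay on A549 cells (Homo sapiens) for cytotoxicity, read by sulforhodamine B assay; a lower number here means a stronger inhibitor, a higher number a weaker inhibitor. Compound 2 `COc1ccc(Cn2c3c(c4ccccc4c2=O)CCOc2ccccc2-3)cc1` gives 11000 nM in this assay, the lowest of the two numbers; compound 1 stands at a higher number, and the gap between the two lies beyond the usual scatter. Among the compounds with values here, compound 1 and compound 2 differ in more than one place, so no single step can be read off between them; their two values only show that compound 2 is the one with the lower number.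

The next step leads from compound 2 to compound 3 `COc1ccc(Cn2c3c(c4ccc(C)cc4c2=O)CCOc2ccccc2-3)cc1`. The change is methyl in place of hydrogen on an aromatic carbon. Nothing in the measured pair isolates the effect of this change on its own, so no step size is known from the data. Given the small size of the group that enters, the step from compound 2 to compound 3 is expected to be no change at the digits printed from compound 2 to compound 3 (within the scatter), that is, none beyond the scatter in either direction. On that basis compound 3 is estimated at 11000 nM in this assay, with a range of 4500 nM to 27000 nM.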

Compound 3, half-maximal inhibitory concentration: 4560 nM
Compound 3: the middle estimate sits 2.4-fold (0.38 log units) above what was measured, within the range that was stated.
By their numbers in this assay, from the lowest: compound 3; then compound 2; then compound 1.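

In this assay the methyl in place of hydrogen on an aromatic carbon gives a 2.4-fold lower number from compound 2 to compound 3 (0.38 log units; beyond the scatter) and so lies beyond the scatter, which shows that this aromatic carbon, meta to a fused ring and para to a fused ring, is not indifferent to the entry of a single carbon atom. Compound 3 also carries the methyl of compound 1, so the 4-methoxyphenyl in place of hydrogen on a saturated chain carbon bound to an aromatic nitrogen can now be read on its own, as a 6.6-fold lower number from compound 1 to compound 3 (0.82 log units; beyond the scatter) in the same assay, a modest step that the first two compounds could not give. Nothing available on the series bears on the reason for either step.

The compounds shown leave open how a longer chain such as ethyl, a methoxy group or an amine would behave on this aromatic carbon. Within the data shown here, only one pair reports on the methyl, so it also remains open whether the same step would appear with hydrogen or another group in place of the 4-methoxyphenyl on the saturated chain carbon.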